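Thioether substituent variation on the shared core: compound 4

The source may hold more compounds than are shown below. What is called first, only, known or untested is meant among the compounds shown, and "the series" means these compounds.

Compound 1 `O=c1c2ccccc2[se]n1-c1nc(SCc2ccccc2)n[nH]1` gives 32000 nM in a functional assay on SMMC-7721 cells (Homo sapiens) for antiproliferative activity, read by CCK-8 assay, with a stated time of 48 h (on this read-out lower numbers stand for stronger inhibition and higher numbers for weaker inhibition), and stands with the highest number of the three measured. Compound 2 `CCSc1n[nH]c(-n2[se]c3ccccc3c2=O)n1` gives 10000 nM, and compound 3 `CCCCCCSc1n[nH]c(-n2[se]c3ccccc3c2=O)n1` gives 22400 nM. Compound 4 `CCCSc1n[nH]c(-n2[se]c3ccccc3c2=O)n1` differs from compound 1 by ethyl in place of phenyl on a saturated chain carbon bound to a sulfur. Among the measured compounds shown here, two measured steps bear directly on this change: a 3.2-fold lower number from compound 1 to compound 2 (0.51 log units; beyond the scatter), a modest drop beyond the scatter, and a 1.4-fold lower number from compound 1 to compound 3 (0.15 log units; within the scatter), which stays within it. A further comparison, a 2.2-fold higher number from compound 2 to compound 3 (0.35 log units; beyond the scatter), shows that lengthening the saturated chain at this place pushes the number back up. The change to compound 4 lies between those two measured cases, so a modest move toward a lower number is expected, a 2.3-fold lower number from compound 1 to compound 4 (0.36 log units; beyond the scatter). Compound 4 is accordingly estimated at 14000 nM, with a range from 7000 nM to 28000 nM.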

Compound 4, half-maximal inhibitory concentration: 6020 nM
Compound 4: middle estimate off by 2.3-fold (0.37 log units), on the high side, outside the stated range (below it).
By their numbers in this assay, from the lowest: compounds 4 and 2 (each within the scatter of the next); then compounds 3 and 1 (each within the scatter of the next).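

In this assay, the drop on leaving benzyl holds for propyl (a 5.3-fold lower number from compound 1 to compound 4 (0.73 log units; beyond the scatter)), and the propyl chain of compound 4 also separates from the longer chain of compound 3 (a 3.7-fold lower number from compound 3 to compound 4 (0.57 log units; beyond the scatter)). The remaining step (a 1.7-fold lower number from compound 2 to compound 4 (0.22 log units; within the scatter)) stays within the scatter, so the short chains of compound 2 and compound 4 cannot be told apart, and only compound 3 goes against a lower number for chains in place of benzyl. No measurement given here explains these steps.
Still open, on these data alone, is how a branched chain, or an amine or carboxylic acid at the chain end, would fare at this place.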